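The compounds below may be only part of what the source reports. "The series", "measured", "known", "first", "only" and "open" are said of these compounds alone.

Working notes on the series, read in an ADME assay on Vero cells (Chlorocebus sabaeus) for cytotoxicity, read by fluorescence and resazurin assay, with a stated time of 3 days; on this read-out lower numbers stand for higher toxicity in this test and higher numbers for lower toxicity in this test. Compound 1 (`CC(=O)c1ccc(-n2cnc3c(N)ncnc32)cc1`) has no number, its entry reading "not determined" (no result reported). Among the compounds with values here, compound 2 (`CCOC(=O)C[C@H]([C@H]1O[C@@H]2OC(C)(C)O[C@@H]2[C@H]1OCc1ccccc1)n1cnc2c(NCc3ccccc3)ncnc21`) gives 53300 nM and compound 3 (`CCCCCCCCCCCCNc1ncnc2c1ncn2[C@H](CC(=O)OCC)[C@H]1O[C@@H]2OC(C)(C)O[C@@H]2[C@H]1OCc1ccccc1`) gives 45000 nM, so compound 2 stands within the scatter of the only other number available and takes no clear rank.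

Compound 4 (`CC1(C)O[C@H]2O[C@H]([C@@H](CCO)n3cnc4c(NCc5ccccc5)ncnc43)[C@H](OCc3ccccc3)[C@H]2O1`) departs from compound 2 at one place: hydroxymethyl in place of ethoxycarbonyl on a saturated chain carbon, two bonds along the chain from an aromatic nitrogen and a saturated ring carbon. In words, hydroxymethyl comes in place of ethoxycarbonyl on a saturated chain carbon, two bonds along the chain from an aromatic nitrogen and a saturated ring carbon. Cut one bond further out, the same difference reads (ethoxycarbonyl)methyl to 2-hydroxyethyl.

One measured step is available: a 1.2-fold lower number from compound 2 to compound 3 (0.07 log units; within the scatter). Within the data shown here, it swaps undecyl in place of phenyl on a saturated chain carbon bound to a nitrogen on an aromatic ring, which is a different place, so it shows only that one change elsewhere left the number within the scatter. Among the measured compounds shown here, no measured step touches the ethoxycarbonyl group, and the expectation in this assay is therefore weakly founded. No shift in either direction beyond the scatter is expected: the estimate is a 1.0-fold higher number from compound 2 to compound 4 (0.01 log units; within the scatter). For compound 4 the expected value is 55000 nM, with an estimated range from 22000 nM to 130000 nM.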

Compound 4, half-maximal cytotoxic concentration: 74900 nM
The estimate for compound 4 lay 1.4-fold (0.13 log units) below the measured number; low and high end bracket the measured number.
By their numbers in this assay, from the lowest: compounds 3, 2 and 4 (each within the scatter of the next).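

In this assay, within the data shown here, this is the first measured step at this position, and it is a 1.4-fold higher number from compound 2 to compound 4 (0.15 log units; within the scatter) with hydroxymethyl in place of ethoxycarbonyl on a saturated chain carbon, two bonds along the chain from an aromatic nitrogen and a saturated ring carbon. The earlier step changed another place, whereas this one shows that replacing a group of 5 heavy atoms and 0 hydrogen-bond donors with one of 2 heavy atoms and 1 hydrogen-bond donor leaves the number within the scatter, at least for the pair formed by compound 2 and compound 4. Nothing at hand bears on the reason for this result.

Still open, from the compounds shown here alone, is whether a carboxylic acid, an amine or a longer chain at this position would move the number beyond the scatter, since a single exchange cannot show how far this position stays insensitive. Going by these compounds, it is also open whether 2-hydroxyethyl would give the same result on the undecyl-bearing compound 3, as the present step rests only on the phenyl-bearing pair.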